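Compound 3: a new group on the sulfonamide nitrogen

A few compounds are considered here, and "the series" means these few. Any claim that something is new, unique, unknown or untested is made for them only; others in the source may bear on it.

Measured in an ADME assay on microsomes from liver (Mus musculus, strain CD-1) for metabolic stability, read by LC-MS, tested at 2 uM; on this read-out higher numbers stand for a longer-lived compound and lower numbers for a shorter-lived compound:
- compound 1 `CN1CCC(CNS(=O)(=O)c2ccccc2Nc2cc(-c3ccc4ccn(C)c4c3)c3nccnc3c2)C1`: 0.633 h
- compound 2 `CN1CCCC(NS(=O)(=O)c2ccccc2Nc2cc(-c3ccc4ccn(C)c4c3)c3nccnc3c2)C1`: 0.483 h

Compound 2 gives 0.483 h, level with compound 1 within the scatter. Compound 3 `Cn1cc(CNS(=O)(=O)c2ccccc2Nc2cc(-c3ccc4ccn(C)c4c3)c3nccnc3c2)cn1` carries (1-methyl-1H-pyrazol-4-yl)methyl in place of 1-methylpiperidin-3-yl on a sulfonamide nitrogen. Among the compounds with values here, only one measured step bears on this, a 1.3-fold lower number from compound 1 to compound 2 (0.12 log units; within the scatter). That step brought in no aromatic ring, so it is a weak guide and gives no direction. The expected change is a 1.1-fold higher number from compound 2 to compound 3 (0.06 log units; within the scatter), with no step beyond the scatter foreseen. In this assay compound 3 is estimated at 0.55 h, with a range of 0.22 h to 1.4 h.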

Compound 3, half-life: 0.267 h
The estimate for compound 3 lay 2.1-fold (0.31 log units) above the measured number, and the stated range covers the measured number.
By their numbers in this assay, from the lowest: compounds 3, 2 and 1 (each within the scatter of the next, the first and the last beyond it).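

In this assay, a five-membered aromatic ring on this sulfonamide nitrogen gives a 1.8-fold lower number from compound 2 to compound 3 (0.26 log units; within the scatter), while the same kind of change gives a 2.4-fold lower number from compound 1 to compound 3 (0.37 log units; beyond the scatter). Within the data shown here, the second is the first step at this position to clear the scatter, and it keeps the saturated chain carbon while replacing 1-methylpyrrolidin-3-yl with 1-methyl-1H-pyrazol-4-yl. Nothing measured here explains the shorter half-life. Three compounds cannot show whether this holds for aromatic rings generally or for this pyrazole alone. A benzyl group or a 2-(dimethylamino)ethyl chain at this nitrogen could fall near either compound 3 or compound 1.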